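A few compounds are considered here, and "the series" means these few. Any claim that something is new, unique, unknown or untested is made for them only; others in the source may bear on it.

Measured compounds:
compound 1 `CCOc1ccc(-c2cc(C(=O)O)nn2-c2ccc(Oc3ccccc3)cc2)cc1` — 694 nM
compound 2 `CC(C)Oc1ccc(-c2cc(C(=O)O)nn2-c2ccc(C(C)C)cc2)cc1` — 5250 nM
compound 3 `CCOc1ccc(-c2c(NC(=O)c3ccccc3)c(C(=O)O)nn2-c2ccc(Oc3ccccc3)cc2)cc1` — 855 nM

In an assay for displacement of a labelled ligand from Apoptosis regulator Bcl-2 (Homo sapiens), read by fluorescence polarization, with a stated time of 30 min (a lower number here means a stronger inhibitor, a higher number a weaker inhibitor), compound 3 gives the second highest of the three numbers. Its nearest neighbour is compound 1, and the step of a 1.2-fold higher number from compound 1 to compound 3 (0.09 log units; within the scatter) lies within the scatter, so the two cannot be ordered. Compound 2 gives a higher number than compound 3, and that gap lies beyond the scatter; no single change separates the two, so the data only show their two values side by side.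

Compound 4 `CCOc1ccc(-c2c(NC(=O)c3ccc(OC(C)C)cc3)c(C(=O)O)nn2-c2ccc(Oc3ccccc3)cc2)cc1` carries the change (isopropoxy in place of hydrogen on an aromatic carbon). Among the compounds with values here, the only measured step that touches the benzamido group is the one from compound 1 to compound 3, which was within the scatter, and no measured step adds an isopropoxy group on its own. There is therefore no basis for expecting a step beyond the scatter in this assay, in either direction, and the estimated step of a 1.0-fold lower number from compound 3 to compound 4 (0.00 log units; within the scatter) reflects that. Compound 4 is expected to give about 850 nM, with a range from 300 nM to 2500 nM.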

Compound 4, inhibition constant: 28 nM
Estimate against measurement, compound 4: 30-fold (1.48 log units) above, outside the stated range (below it).
By their numbers in this assay, from the lowest: compound 4; then compounds 1 and 3 (each within the scatter of the next); then compound 2.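

In this assay, the change from phenyl to 4-isopropoxyphenyl, with isopropoxy para to a large group, gives a 31-fold lower number from compound 3 to compound 4 (1.48 log units; beyond the scatter) and so shows that this ring position responds strongly to substitution. The earlier step that brought in the unsubstituted benzamido group, a 1.2-fold higher number from compound 1 to compound 3 (0.09 log units; within the scatter), gave no sign of this, as that step lies within the scatter; the size of the effect appears only once isopropoxy is present on that ring. No measurement shown here accounts for the size of this step.

The compounds shown leave open whether the gain is particular to isopropoxy or would also come with methoxy, a longer chain such as butoxy, or an amine at the same place. They also leave open whether a step of this size would hold with the phenoxy group replaced by another group, such as a cyclohexyl ring.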